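The compounds below may be only part of what the source reports. "The series", "measured", "known", "first", "only" and "open" are said of these compounds alone.

Of the compounds shown here, two have been measured in an assay on HEK293 cells for inhibition of Steryl-sulfatase (Homo sapiens), tested at 0.1 uM; a higher number here means a stronger effect of the compound at the concentration tested, a lower number a weaker effect. Compound 1 `NS(=O)(=O)Oc1ccc2c(c1)CN(C(=O)c1cccc(N3CCC(N4CCCCC4)CC3)c1)CC2` gives 0% in this assay, while compound 2 `CCN(Cc1ccccn1)c1ccc(C(=O)N2CCc3ccc(OS(N)(=O)=O)cc3C2)cc1` gives 42.5%. Compound 2 therefore stands highest of the two numbers; its nearest neighbour is compound 1, whose number lies lower by more than the usual scatter. The next compound, compound 3 `CN(CCCN1CCCCC1)c1ccc(C(=O)N2CCc3ccc(OS(N)(=O)=O)cc3C2)cc1`, has not yet been measured. It differs from compound 2 in one place: methyl(3-(piperidin-1-yl)propyl)amino in place of ethyl((pyridin-2-yl)methyl)amino on an aromatic carbon. Among the compounds with values here, no step between two measured compounds matches this change, so the expected size of the step rests on little. Because compound 1 gives 0% in this assay, a drop from compound 2 seems more likely than a rise, though a step within the scatter cannot be ruled out. Compound 3 is expected to give about 20% in this assay, with a likely range from 0% to 45%. The expected step is a number 22.5 percentage points lower from compound 2 to compound 3 (beyond the scatter).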

Compound 3, a percentage reported as inhibition, at one concentration (the size of the read-out at that concentration, not a potency): 17.4%
For compound 3 the middle estimate is 2.6 percentage points above the measured one; low and high end bracket the measured number.
By their numbers in this assay, from the lowest: compound 1; then compound 3; then compound 2.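

Compound 3 shows that the group on this aromatic carbon, para to a large group, can change the read-out in this assay by more than the usual scatter. Putting methyl(3-(piperidin-1-yl)propyl)amino in place of ethyl((pyridin-2-yl)methyl)amino gives a number 25.1 percentage points lower from compound 2 to compound 3 (beyond the scatter) even though the two groups are close in heavy-atom count and have the same numbers of hydrogen-bond donors and acceptors. The swap changes both the ring and the chain that carries it, so this single step cannot show which part matters, and no outside measurement offers an explanation.

From the compounds shown here alone, it remains open how much the ring counts compared with the chain. A benzyl group, with its carbon-only aromatic ring, or a plain dimethylamino group on the same carbon would help to separate the two.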